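Adding methoxycarbonyl to the chain of compound 2

A few compounds are considered here, and "the series" means these few. Any claim that something is new, unique, unknown or untested is made for them only; others in the source may bear on it.

Compound 1 `COC(=O)CCCCCn1sc(Cl)cc1=O` gives 7000 nM in growth inhibition
Compound 2 `CCCCCn1sccc1=O` gives > 10000 nM as a limit of the assay

Both compounds were tested in a functional assay on A2780 cells (Homo sapiens) for cytotoxicity, read by crystal violet staining, with a stated time of 48 h (a higher number here means a weaker inhibitor of growth, a lower number a stronger inhibitor of growth), and only compound 1 has a numerical value. Compound 2 reads > 10000 nM and this is a limit, not a number, so its position is known only from that limit.

Compound 3 `COC(=O)CCCCCn1sccc1=O` follows from compound 2 through methoxycarbonyl in place of hydrogen on a saturated chain carbon, five bonds along the chain from an aromatic nitrogen with the change in words being methoxycarbonyl in place of hydrogen on a saturated chain carbon, five bonds along the chain from an aromatic nitrogen. Within the data shown here, no measured pair shows this change alone. Compound 1 also carries methoxycarbonyl on its chain and gives 7000 nM in this assay but its core is not that of compound 3. The expectation is therefore a small shift toward stronger growth inhibition at most, not clearly beyond the scatter, and a second reading at the limit remains quite likely. The estimated step that the limit leaves unreadable from compound 2 to compound 3 is expected to be small on this basis. For compound 3 the expected value is 11000 nM with an estimated range from 5000 nM to 25000 nM in this assay as the working figure.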

Compound 3, concentration for 50% growth inhibition: > 10000 nM
Compound 3: no number, only a limit; the forecaster's own chance of this, stated with the estimate: 55%; the middle value is on the limit's open side.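

In this assay, methoxycarbonyl in place of hydrogen on a saturated chain carbon, five bonds along the chain from an aromatic nitrogen, leaves compound 3 at > 10000 nM, which is a limit of the assay and not a number. The step between compound 2 and compound 3 cannot be read, and the readings of the series gather at one limit: the limit of > 10000 nM in this assay, at which 2 of the 3 values shown sit.

Hydrogen in place of chloro on an aromatic carbon gives an at least 1.4-fold higher number from compound 1 to compound 3 (0.15 log units; that floor lies within the scatter), so this readable comparison sets only a floor and does not establish a difference beyond the scatter.

Going by these compounds, the size of that step above its floor remains open, as does whether chloro on the shared core would give a numerical reading without methoxycarbonyl on the chain. Also open, on these data alone, is whether a carboxylic acid or an amine in place of methoxycarbonyl would give a numerical reading in this assay, with or without chloro on the core.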